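Adding a Methoxy Group to the Benzyl Ring of Compound 3

The source may hold more compounds than are shown below. What is called first, only, known or untested is meant among the compounds shown, and "the series" means these compounds.

Compound 1, `CCn1c(CN2CCN(C(=O)C3CC3)CC2)nc2ccccc21`, in an assay on isolated protein for inhibition of aldehyde dehydrogenase 1A1 (Homo sapiens), read by spectrophotometry, tested at 10 uM; on this read-out higher numbers stand for more inhibition at the one concentration tested (going by the name of the read-out) and lower numbers for less inhibition: 20.8%
Compound 2, `O=C(C1CC1)N1CCN(Cc2nc3ccccc3n2Cc2ccccc2C(F)(F)F)CC1`, in this assay: 56.3%
Compound 3, `O=C(C1CC1)N1CCN(Cc2nc3ccccc3n2Cc2ccccc2)CC1`, in this assay: 23.9%

Compound 3 stands second highest of these three numbers. Its nearest neighbour is compound 1, and the step of a number 3.1 percentage points higher from compound 1 to compound 3 (within the scatter) lies within the scatter, so the two cannot be ranked. The furthest is compound 2, reached by undoing the step of a number 32.4 percentage points lower from compound 2 to compound 3 (beyond the scatter).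

Compound 4, `COc1cccc(Cn2c(CN3CCN(C(=O)C4CC4)CC3)nc3ccccc32)c1`, differs from compound 3 in one place: methoxy in place of hydrogen on an aromatic carbon. The change sits on the same ring that carries the trifluoromethyl group in compound 2, so two measured steps bear on it. The step of a number 3.1 percentage points higher from compound 1 to compound 3 (within the scatter) shows that the bare benzyl group on its own does little. The step of a number 32.4 percentage points lower from compound 2 to compound 3 (beyond the scatter) shows that a substituent on that ring can matter a great deal, though the group and its place there differ from those of compound 4. A rise is therefore plausible but far from certain, and for compound 4 the step of a number 6.1 percentage points higher from compound 3 to compound 4 (within the scatter) is expected to be modest at most. For compound 4 the estimate in this assay is 30%, with a range from 12% to 55%.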

Compound 4, a percentage reported as inhibition, at one concentration (the size of the read-out at that concentration, not a potency): 44.4%
Compound 4: middle estimate off by 14.4 percentage points, on the low side; the range from low to high includes it.
By their numbers in this assay, from the lowest: compounds 1 and 3 (each within the scatter of the next); then compound 4; then compound 2.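

In this assay, turning benzyl into 3-methoxybenzyl gives a number 20.5 percentage points higher from compound 3 to compound 4 (beyond the scatter), so this ring position responds to a methoxy group, and a substituent other than trifluoromethyl can raise the number on this ring. The bare benzyl group could not be told apart from the small chain of compound 1, whereas the 3-methoxybenzyl group can, with a number 23.6 percentage points higher from compound 1 to compound 4 (beyond the scatter), so here the gain comes with the substituent and not with the ring alone. Going the other way gives a number 11.9 percentage points lower from compound 2 to compound 4 (beyond the scatter), which keeps the 2-(trifluoromethyl)phenyl group on top, but that step swaps the group and its place on the ring together, and nothing available explains the differences seen among these compounds.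

Going by these compounds, it remains open whether the gain belongs to methoxy itself or to having any group at this position, a question that a hydroxy group or an amine in the same place could help settle. It is also unknown how methoxy would behave in the ring position that trifluoromethyl holds in compound 2, which would separate the effect of the group from the effect of its place.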